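A New Aminopyridine Arm on the Shared Core

This account rests on a few compounds, and the source may have more. Where it says the series, first, only, none or still open, it means among the compounds named here.

Among the compounds with values here, in an in vitro assay on HEK385-7 cells for displacement of a labelled ligand from prostaglandin D2 receptor 2 (Homo sapiens) (on this read-out higher numbers stand for weaker inhibition and lower numbers for stronger inhibition), compound 1 `O=C(O)Cc1sc(C(c2ccc(F)cc2)c2ccc(F)cc2)nc1-c1ccnc(N2CCC2)c1` gives 660 nM, the second highest of the three numbers measured so far. Compound 2 `O=C(O)Cc1sc(C(c2ccccc2)c2ccccc2)nc1-c1ccc(C(F)(F)F)cc1` gives 1100 nM, which lies within the scatter of compound 1, while compound 3 `O=C(O)Cc1sc(C(c2ccccc2)c2ccccc2)nc1-c1ccc(F)c(F)c1` gives 4.1 nM, far lower than either. Within the data shown here, the one single-point step recorded, a 270-fold lower number from compound 2 to compound 3 (2.43 log units; beyond the scatter), shows that the aromatic group attached to the shared core on an aromatic carbon, next to the ring nitrogen, can move the read-out a long way. Compound 4 `Cc1cc(-c2nc(C(c3ccc(F)cc3)c3ccc(F)cc3)sc2CC(=O)O)cnc1N` differs from compound 1 at that same place: 6-amino-5-methylpyridin-3-yl in place of 2-(azetidin-1-yl)pyridin-4-yl on an aromatic carbon. Among the measured compounds shown here, no measured pair shows this particular exchange, so its direction is open; only the size of the earlier step at this position suggests that a change beyond the scatter is possible. The estimate for compound 4 is therefore a modestly lower number, 300 nM, expected to fall between 30 nM and 3000 nM. That estimate corresponds to an expected step of a 2.2-fold lower number from compound 1 to compound 4 (0.34 log units; beyond the scatter).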

Compound 4, half-maximal inhibitory concentration: 880 nM
Compound 4: middle estimate off by 2.9-fold (0.47 log units), on the low side; low and high end bracket the measured number.
By their numbers in this assay, from the lowest: compound 3; then compounds 1, 4 and 2 (each within the scatter of the next).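

In this assay, putting 6-amino-5-methylpyridin-3-yl in place of 2-(azetidin-1-yl)pyridin-4-yl gives a 1.3-fold higher number from compound 1 to compound 4 (0.12 log units; within the scatter) and so leaves the read-out unmoved, although this same position earlier produced a 270-fold lower number from compound 2 to compound 3 (2.43 log units; beyond the scatter) in another pair. Large steps here therefore do not follow from every exchange: the four-membered ring can leave and a hydrogen-bond donor can enter with no change beyond the scatter, at least between these two groups on the core of compound 1. Nothing available explains this result.

As far as these compounds go, whether the 3,4-difluorophenyl group would also give a low number on the core of compound 1, with its two 4-fluorophenyl groups, stays open. So does the effect of a morpholine ring in place of the azetidine, or of a 6-aminopyridin-3-yl group without the methyl.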